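Trimming the Chain Between Compound 3 and Compound 4

The source may report more compounds than this note shows. Statements on the series, on what has been measured and on what is new or still open speak of the compounds shown alone.

Compound 1 `COc1cc(NC(C)CCCNC(=O)NNC(=O)Nc2cccc(C(F)(F)F)c2)c2ncccc2c1` gives 4000 nM in a functional assay on L1210 cells (Mus musculus) for inhibition, read by MTT assay, with a stated time of 72 h; a lower number here means a stronger inhibitor, a higher number a weaker inhibitor. Compound 2 `COc1cc(NC(C)CCCNC(=O)NNC(=O)Nc2ccc(O)cc2)c2ncccc2c1` gives 95000 nM in this assay. Compound 3 `COc1cc(NC(C)CCCNC(=O)NNC(=O)Nc2ccc(F)cc2)c2ncccc2c1` gives 104000 nM in this assay.

Compound 3 carries the highest number of the three; compound 2 lies within the scatter of it, while the step of a 26-fold higher number from compound 1 to compound 3 (1.41 log units; beyond the scatter) is large. Compound 4 `COc1cc(NC(C)CCCNC(=O)Nc2ccc(Cl)cc2)c2ncccc2c1` differs from compound 3 in one place: 4-chlorophenyl in place of ((4-fluorophenyl)carbamoyl)amino on an amide-type nitrogen. Among the measured compounds shown here, no measured step alters this part of the molecule. The steps of a 24-fold higher number from compound 1 to compound 2 (1.38 log units; beyond the scatter) and a 26-fold higher number from compound 1 to compound 3 (1.41 log units; beyond the scatter) show that the aryl-bearing end governs the number strongly, whereas a 1.1-fold higher number from compound 2 to compound 3 (0.04 log units; within the scatter) shows that swapping one para substituent for another hardly matters. Compound 4 is therefore expected to give 50000 nM in this assay, between 8000 nM and 250000 nM, a step of a 2.1-fold lower number from compound 3 to compound 4 (0.32 log units; beyond the scatter) that remains uncertain in direction.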

Compound 4, half-maximal inhibitory concentration: 19000 nM
Compound 4: middle estimate off by 2.6-fold (0.42 log units), on the high side; low and high end bracket the measured number.
By their numbers in this assay, from the lowest: compound 1; then compound 4; then compounds 2 and 3 (each within the scatter of the next).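

Among the compounds shown here, the first change to the linking part of the molecule moves the number by far more than the scatter: 4-chlorophenyl in place of ((4-fluorophenyl)carbamoyl)amino gives a 5.5-fold lower number from compound 3 to compound 4 (0.74 log units; beyond the scatter) in this assay. The same kind of change from the hydroxy-bearing compound gives a 5.0-fold lower number from compound 2 to compound 4 (0.70 log units; beyond the scatter), so the number responds at this amide-type nitrogen, not only at the substituent on the aryl ring. The data offer no explanation for this step.

Each step also brings in chlorine, so the effect of the shorter link stays mixed with that of the ring substituent. As far as these compounds go, how a longer chain or an amine on this nitrogen would read remains open.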